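From Butyl to Cyanophenyl on a Thiourea Nitrogen

This account rests on a few compounds, and the source may have more. Where it says the series, first, only, none or still open, it means among the compounds named here.

Compound 2 `CCCCNC(=S)NCc1cnc2scc(C#CC3CC3)n12` gives 502 nM in an assay on cells for inhibition of Indoleamine 2,3-dioxygenase 1 (Homo sapiens) (on this read-out lower numbers stand for stronger inhibition and higher numbers for weaker inhibition), the lowest of the two numbers in hand. Compound 1 `Cc1ccc(CS(=O)(=O)NCc2cnc3scc(-c4ccc(Br)cc4)n23)cc1` gives 855 nM in this assay, a gap that lies within the scatter, so neither compound can be called the more potent. Compound 3 `N#Cc1ccc(NC(=S)NCc2cnc3scc(C#CC4CC4)n23)cc1` carries 4-cyanophenyl in place of butyl on an amide-type nitrogen. For the measured compounds named here, no measured pair shows this kind of change, so the numbers in hand give no size or direction for it. Compound 3 is expected at an estimated 450 nM, between 120 nM and 1700 nM. The expected step of a 1.1-fold lower number from compound 2 to compound 3 (0.05 log units; within the scatter) stays within the scatter.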

Compound 3, half-maximal inhibitory concentration: 16.4 nM
Compound 3: middle estimate off by 27-fold (1.44 log units), on the high side; the measured number lies below the stated range.
By their numbers in this assay, from the lowest: compound 3; then compounds 2 and 1 (each within the scatter of the next).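

The thiourea nitrogen is a place where the group matters greatly: with the rest of the molecule unchanged, 4-cyanophenyl in place of butyl gives a 31-fold lower number from compound 2 to compound 3 (1.49 log units; beyond the scatter). This is the first single-place change among these compounds, and it shows that this position can shift the read-out well beyond the scatter. No measurement here explains the size of this step.

As far as these compounds go, it remains open whether the phenyl ring or the nitrile accounts for the step. A plain phenyl on the same nitrogen would separate the two.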